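Benzyl swap on the nucleoside series, antiproliferative read-out

The compounds below may be only part of what the source reports. "The series", "measured", "known", "first", "only" and "open" are said of these compounds alone.

For the measured compounds named here, compound 1 `OC[C@H]1O[C@@H](n2cnc3c(NCc4ccc(Cl)cc4Cl)ncnc32)[C@H](O)[C@@H]1O` is the only member with a numeric result in a functional assay on G-361 cells (Homo sapiens) for antiproliferative activity, with a stated time of 72 h; on this read-out higher numbers stand for weaker inhibition and lower numbers for stronger inhibition: compound 1 gives 128000 nM. Compound 2 `COc1cc(CNc2ncnc3c2ncn3[C@@H]2O[C@H](CO)[C@@H](O)[C@H]2O)cc(OC)c1O` reaches only the limit of the assay in this assay, compound 2 returning > 166000 nM. Compound 3 `COc1cc(O)cc(OC)c1CNc1ncnc2c1ncn2[C@@H]1O[C@H](CO)[C@@H](O)[C@H]1O` likewise stops at the limit in this assay, compound 3 giving > 166000 nM. Two of the three results therefore sit at the limit of > 166000 nM in this assay, at which 2 of the 3 values shown sit, and compound 1 stands as the single number shown, itself a weak inhibitor on this read-out. Going by the values given here, no pair of measured compounds differs in one place, so no measured step exists.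

Compound 4 `Cc1ccc(O)c(CNc2ncnc3c2ncn3[C@@H]2O[C@H](CO)[C@@H](O)[C@H]2O)c1` is not yet measured in this assay. It differs from compound 1 by 2-hydroxy-5-methylphenyl in place of 2,4-dichlorophenyl on a saturated chain carbon bound to a nitrogen on an aromatic ring. With the two other benzyl variants at the limit and compound 1 weak, no step beyond the scatter is expected in either direction. The expected step is a 1.2-fold higher number from compound 1 to compound 4 (0.07 log units; within the scatter), with a real chance that only a limit is reported. Compound 4 is estimated at 150000 nM in this assay, between 60000 nM and 400000 nM.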

Compound 4, half-maximal inhibitory concentration: > 166000 nM
Compound 4: no number, only a limit; the forecaster's own chance of this, stated with the estimate: 55%; middle value at least 1.1-fold (0.04 log units) away from the limit.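

For the compounds shown here, replacing 2,4-dichlorophenyl with 2-hydroxy-5-methylphenyl on a saturated chain carbon bound to a nitrogen on an aromatic ring gives the first readable step in this assay: an at least 1.2-fold higher number from compound 1 to compound 4 (0.11 log units; that floor lies within the scatter). The result for compound 4 is a limit and not a number, so this step has only a floor and its true size cannot be read. With this change, compound 1 remains the only member with a numeric result, and the other results stop at the same limit: the limit of > 166000 nM in this assay, at which 3 of the 4 values shown sit.

On these data alone, whether any change at this position gives a number clearly stronger than that of compound 1 stays open. An amine or a carboxylic acid on the phenyl ring, or a longer chain in place of the benzyl link, would test this; the compounds shown include none of these.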